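Moving One Methyl Group on a Potent Compound

The compounds below may be only part of what the source reports. "The series", "measured", "known", "first", "only" and "open" are said of these compounds alone.

Measured in a functional assay on KB-VIN cells (Homo sapiens) for cytotoxicity, read by sulforhodamine B assay (on this read-out lower numbers stand for an effect already at smaller amounts and higher numbers for an effect only at larger amounts of compound), so far:
Compound 1 `CC1=C(O)c2c(oc(-c3ccc(C)cc3)cc2=O)C(C)(C)C1=O` gives 1.09 ug/mL
Compound 2 `CC1=C(O)c2c(oc(-c3ccccc3C)cc2=O)C(C)(C)C1=O` gives 1.75 ug/mL
Compound 3 `CCC1=C(O)c2c(oc(-c3ccc(C)cc3)cc2=O)C(CC)(CC)C1=O` gives 0.03 ug/mL

Compound 3 has the lowest number of the three, and its gaps to compound 1 and compound 2 both lie beyond the scatter. Compound 4 `CCC1=C(O)c2c(oc(-c3ccccc3C)cc2=O)C(CC)(CC)C1=O`, not yet measured, has 2-methylphenyl in place of 4-methylphenyl on an aromatic carbon of the same core. Among the measured compounds shown here, one measured step bears on this, the same exchange on the different core of compound 1: a 1.6-fold higher number from compound 1 to compound 2 (0.21 log units; within the scatter). This single example gives thin support, but no step beyond the scatter is expected in this assay. The estimate is a small rise, a 1.7-fold higher number from compound 3 to compound 4 (0.22 log units; within the scatter), still within the scatter. For compound 4 the expected value is 0.05 ug/mL, with an estimated range from 0.015 ug/mL to 0.2 ug/mL.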

Compound 4, concentration for half-maximal effect: 0.1 ug/mL
For compound 4 the middle estimate is 2.0-fold (0.30 log units) below the measured one; the measured number falls inside the stated range.
By their numbers in this assay, from the lowest: compound 3; then compound 4; then compounds 1 and 2 (each within the scatter of the next).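

In this assay, putting 2-methylphenyl in place of 4-methylphenyl gives a 3.3-fold higher number from compound 3 to compound 4 (0.52 log units; beyond the scatter), so on this core the place of the methyl group on the phenyl ring makes a readable difference, which the same exchange on the core of compound 1 did not show. The two cores still cannot be said to respond differently to this change: the same change on two cores in this assay, a 1.6-fold higher number (0.21 log units; within the scatter) from compound 1 to compound 2 and a 3.3-fold higher number (0.52 log units; beyond the scatter) from compound 3 to compound 4, 2.1-fold (0.32 log units) apart, within the scatter of two such steps

Every compound shown carries a methyl group on this phenyl ring. From the compounds shown here alone, what an amine, a carboxylic acid or a longer chain would do there remains open.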